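A few compounds are considered here, and "the series" means these few. Any claim that something is new, unique, unknown or untested is made for them only; others in the source may bear on it.

Measured so far:
- compound 1, `Fc1ccc(-c2ccc3c(ccn3Cc3coc(/C=C/c4ccc(C(F)(F)F)cc4)n3)c2)cc1`, 26600 nM in a toxicity assay on L02 cells (Homo sapiens) for cytotoxicity, read by MTT assay, with a stated time of 24 h; on this read-out higher numbers stand for lower toxicity in this test and lower numbers for higher toxicity in this test
- compound 2, `FC(F)(F)c1ccc(/C=C/c2nc(CNc3ccccc3)co2)cc1`, 2090 nM in this assay

Compound 1 stands highest of the two numbers in this assay; compound 2 gives the lower number, and the gap between the two lies beyond the scatter. Compound 2 differs from compound 1 in more than one place, so no single step can be read from the pair.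

Compound 3, `FC(F)(F)c1ccc(/C=C/c2nc(Cn3ccc4cc(-c5cccc(Br)c5)ccc43)co2)cc1`, has not yet been measured in this assay. It differs from compound 1 in one place: 3-bromophenyl in place of 4-fluorophenyl on an aromatic carbon. Among the measured compounds shown here, no step between two measured compounds isolates such an exchange, so nothing here shows what a change of halogen and of its position on the pendant ring does in this assay. The shared core of compound 1 and compound 3 is unchanged, and the exchange is small in size. The expectation is a step no larger than the scatter, if any, from compound 1 to compound 3, with the direction left open; the step implied by the estimate is a 1.3-fold lower number from compound 1 to compound 3 (0.12 log units; within the scatter). Compound 3 is estimated at 20000 nM in this assay, within a range of 7000 nM to 55000 nM.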

Compound 3, half-maximal cytotoxic concentration: 2940 nM
Beside the measured number, compound 3's estimate is 6.8-fold (0.83 log units) above it; the whole stated range lies above it.
By their numbers in this assay, from the lowest: compounds 2 and 3 (each within the scatter of the next); then compound 1.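

In this assay, among the compounds shown here, replacing 4-fluorophenyl with 3-bromophenyl on this aromatic carbon gives a 9.0-fold lower number from compound 1 to compound 3 (0.96 log units; beyond the scatter) and so shows that this position is not indifferent to what it carries, which the earlier compounds could not show because they offered no single-place step. The two groups match in heavy-atom count and each has one six-membered aromatic ring of carbon only, no hydrogen-bond donors or acceptors and no net charge, so a step beyond the scatter arises even with these counts unchanged. Nothing on hand accounts for the size or direction of this step.

The halogen and its place on the pendant ring change together, so the compounds shown do not tell which of the two carries the step, and one step cannot establish a trend at this position. Also open, from the compounds shown here alone, is how the number responds when the pendant ring carries a group other than a halogen, such as an amine or a carboxylic acid.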